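Two inverted stereocentres from compound 1 to compound 3

The source may hold more compounds than are shown below. What is called first, only, known or untested is meant among the compounds shown, and "the series" means these compounds.

In a functional assay on A549 cells (Homo sapiens) for cytotoxicity, read by MTT assay, with a stated time of 7 days (a lower number here means that less compound is needed, a higher number that more compound is needed for the effect), compound 1 `CC1=C[C@H]2[C@@H](C(C)C)CC[C@@](C)(O)[C@H]2CC1=O` gives 8.78 ug/mL as its concentration for half-maximal effect. Compound 2 `CC(C)[C@@H]1CC[C@@](C)(O)[C@]2(O)[C@@H](O)C[C@@H](C)C[C@@H]12` gives 13.3 ug/mL on the same read-out, and the two values lie within the scatter of each other. Compound 1 is therefore not set apart by these numbers. Within the data shown here, the two structures also differ in more than one place, so the series offers no measured step.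

Compound 3 `CC1=C[C@@H]2[C@@H](CC1=O)[C@](C)(O)CC[C@H]2C(C)C` keeps the atoms and bonds of compound 1, and the two compounds have the same atoms and bonds and differ only in configuration as drawn: 2 of 4 stereo elements differ; a stereocentre at a saturated ring carbon is drawn S in compound 1 and R in compound 3; a stereocentre at a saturated ring carbon is drawn R in compound 1 and S in compound 3 is the whole of the difference. Among the measured compounds shown here, no measured pair isolates a change of configuration, so the data show neither the size nor the direction of its effect.

For the measured compounds named here, the only guide is the narrow spread of the series: compound 1 at 8.78 ug/mL and compound 2 at 13.3 ug/mL stay within the scatter of each other although their structures differ. No step beyond the scatter is therefore expected in this assay here, though the margin must stay wide. The expected step is a 1.1-fold higher number from compound 1 to compound 3 (0.06 log units; within the scatter) as a working estimate. For compound 3 the estimated value is 10 ug/mL with 4 ug/mL to 25 ug/mL as the expected range.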

Compound 3, concentration for half-maximal effect: 32.2 ug/mL
The estimate for compound 3 lay 3.2-fold (0.51 log units) below the measured number; measured number above the stated range.
By their numbers in this assay, from the lowest: compounds 1 and 2 (each within the scatter of the next); then compound 3.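

In this assay the series now holds its first measured step, a 3.7-fold higher number from compound 1 to compound 3 (0.56 log units; beyond the scatter), which shows that configuration alone can move this read-out beyond the scatter. The step can be assigned to configuration and to nothing else because no atom or bond changes within the pair: the fact that compounds 1 and 3 differ only in the configuration as drawn. Its direction also favours the configuration drawn in compound 1, which needs less compound for the effect than its counterpart, but the two stereocentres change together, so the step belongs to the pair of inversions and cannot be divided between them.

The compounds shown leave open how much each stereocentre contributes on its own, and whether inverting the remaining 2 of the 4 stereo elements would move the number further in either direction. Also open, going by these compounds, is whether the preference for the configuration of compound 1 would survive a change of substituent, for example an amine or a carboxylic acid on the shared core, and whether the same step would appear on cells other than the one line tested here.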